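This account rests on a few compounds, and the source may have more. Where it says the series, first, only, none or still open, it means among the compounds named here.

Working notes on the series. All numbers come from a functional assay on HeLa cells (Homo sapiens) for inhibition, read by CCK-8 assay, with a stated time of 72 h, tested at 2 uM; a lower number here means less inhibition of growth, a higher number more inhibition of growth at the concentration tested. Compound 2 `Nc1ccccc1NC(=O)/C=C/c1ccc(CSCCc2ccccc2)cc1` gives 0.19%. Compound 1 `Nc1ccccc1NC(=O)/C=C/c1ccc(CSc2ccc(F)cc2)cc1` gives 7.09%, so the change 4-fluorophenyl in place of phenethyl on a sulfur made a step of a number 6.9 percentage points higher from compound 2 to compound 1 (within the scatter). Compound 3 `Nc1ccccc1NC(=O)c1ccc(CSCCc2ccccc2)cc1` gives 27.7%, the highest of the three and beyond the scatter from both others. The difference between the core of compound 3 and the core of compound 2 is not broken down here.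

Compound 4 `Nc1ccccc1NC(=O)c1ccc(CSc2ccc(F)cc2)cc1` is not yet measured. It differs from compound 3 by 4-fluorophenyl in place of phenethyl on a sulfur, the same change, at the same place, as from compound 2 to compound 1; the change occurs twice among these compounds. In this assay a step of a number 4.3 percentage points higher from compound 3 to compound 4 (within the scatter) is expected. That expectation rests on the earlier step of a number 6.9 percentage points higher from compound 2 to compound 1 (within the scatter), which stayed within the scatter. Compound 4 is therefore estimated at 32%, between 15% and 50%.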

Compound 4, percent growth inhibition at one concentration: 27.9%
Estimate against measurement, compound 4: 4.1 percentage points above, and the stated range covers the measured number.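

In this assay, 4-fluorophenyl in place of phenethyl on a sulfur gives a number 0.2 percentage points higher from compound 3 to compound 4 (within the scatter). The change therefore carries from one core to the other with no readable difference between the two steps: the same change on two cores in this assay, a number 6.9 percentage points higher (within the scatter) from compound 2 to compound 1 and a number 0.2 percentage points higher (within the scatter) from compound 3 to compound 4, 6.7 percentage points apart, within the scatter of two such steps

This does not show that the change has any effect of its own, since neither step lies beyond the scatter, and it says nothing about other cores or other concentrations. The compounds shown leave open what a group other than phenethyl or 4-fluorophenyl would do on the sulfur, such as a longer chain, an amine or a carboxylic acid. Going by these compounds, whether any such group moves growth inhibition beyond the scatter on either core also remains open.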